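From phenyl to octyl on a shared core

The source may report more compounds than this note shows. Statements on the series, on what has been measured and on what is new or still open speak of the compounds shown alone.

Measured in a physicochemical assay for lipophilicity, measured as octanol-water partition; a lower number here means a more polar compound, a higher number a more lipophilic compound:
Compound 1 `CCCCCc1cn(C/C=C(/C)CC/C=C(\C)CCC=C(C)C)nn1` gives 7.5
Compound 2 `CC(C)=CCC/C(C)=C/CC/C(C)=C\Cn1cc(-c2ccccc2)nn1` gives 6.95

Within the data shown here, compound 2 at 6.95 holds the lower of the two numbers so far, and its gap to compound 1 lies beyond the scatter. Compound 3 `CCCCCCCCc1cn(C/C=C(/C)CC/C=C(\C)CCC=C(C)C)nn1` keeps the shared core and differs from compound 2 in one place (octyl in place of phenyl on an aromatic carbon), with octyl in place of phenyl on an aromatic carbon.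

Among the measured compounds shown here, the one measured step that bears on this is a number 0.55 log units lower from compound 1 to compound 2 (beyond the scatter) and it is a modest one. Read backwards, it suggests that leaving phenyl for an open chain should raise the number. Compound 1 carries pentyl and stands at 7.5 and octyl is a longer chain than pentyl, so compound 3 is expected above that value. For the measured compounds named here, no measured pair shows how much chain length counts here, so the size is uncertain. In this assay the expected move is upward (a number 1.95 log units higher from compound 2 to compound 3 (beyond the scatter)), well beyond the scatter. Compound 3 is estimated at 8.9 (range 8.3 to 9.5).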

Compound 3, partition coefficient: 8.76
For compound 3 the middle estimate is 0.14 log units above the measured one; the measured number falls inside the stated range.
By their numbers in this assay, from the lowest: compound 2; then compound 1; then compound 3.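

In this assay, this position on the aromatic carbon responds to the length of an open chain, and not only to the swap between a ring and a chain: octyl in place of phenyl moves the number much further than the earlier step from pentyl to phenyl did (a number 1.81 log units higher from compound 2 to compound 3 (beyond the scatter)). Keeping the chain and extending it, with propyl in place of hydrogen on a saturated chain carbon, five bonds along the chain from an aromatic carbon, also gives a clear rise (a number 1.26 log units higher from compound 1 to compound 3 (beyond the scatter)), so across these three compounds phenyl stands lowest, the longer of the two chains stands highest, and no compound goes against that order. Nothing available gives a reason for either move.

As far as these compounds go, with only pentyl and octyl as chains, it remains open whether the number keeps rising evenly with each added carbon or levels off with a longer chain such as dodecyl, and how far a short chain such as methyl would bring it down. From the compounds shown here alone, it is also open how an amine or a carboxylic acid at this same aromatic carbon would compare with phenyl and the two chains.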